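Aryl piperazine series: chloro to dimethyl on the aryl ring

The compounds below may be only part of what the source reports. "The series", "measured", "known", "first", "only" and "open" are said of these compounds alone.

Measured so far:
compound 1 `CCCc1nc(-c2ccccc2)c(CNCCN2CCN(c3ccc(Cl)cc3)CC2)o1`: 2820 nM
compound 2 `CCCc1nc(-c2ccccc2)c(CNCCN2CCN(c3ccc(F)cc3)CC2)o1`: 7080 nM
compound 3 `CCCc1nc(-c2ccccc2)c(CNCCCN2CCN(c3cccc(Cl)c3)CC2)o1`: 1750 nM

In an assay on HEK293 cells for inhibition of Voltage-dependent T-type calcium channel subunit alpha-1G (Homo sapiens), read by patch clamp (on this read-out higher numbers stand for weaker inhibition and lower numbers for stronger inhibition), compound 3 gives the lowest number of the three, but its gap to compound 1 lies within the scatter, so the two cannot be ordered; only the gap to compound 2 lies beyond it. Going by the values given here, the one step measured, a 2.5-fold higher number from compound 1 to compound 2 (0.40 log units; beyond the scatter), concerns a halogen swap on the aryl ring and runs toward a higher number.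

Compound 4 `CCCc1nc(-c2ccccc2)c(CNCCCN2CCN(c3ccc(C)c(C)c3)CC2)o1` differs from compound 3 by 3,4-dimethylphenyl in place of 3-chlorophenyl on an amine nitrogen in a ring. Among the compounds with values here, no measured step covers methyl in place of chloro, nor a second substituent on that ring; the step from compound 1 to compound 2 bears on it only loosely, as a change of a single ring substituent on the same aryl piperazine, and that step was modest. Within the data shown here, since nothing among the measured compounds points to a larger effect, the number for compound 4 in this assay is expected to sit close to that of compound 3, with a step of a 1.1-fold higher number from compound 3 to compound 4 (0.06 log units; within the scatter) expected to stay within the scatter. Compound 4 is therefore estimated at 2000 nM, with a range from 700 nM to 6000 nM.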

Compound 4, half-maximal inhibitory concentration: 3020 nM
Beside the measured number, compound 4's estimate is 1.5-fold (0.18 log units) below it; low and high end bracket the measured number.
By their numbers in this assay, from the lowest: compounds 3, 1 and 4 (each within the scatter of the next); then compound 2.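

In this assay, the exchange on an amine nitrogen in a ring gives a 1.7-fold higher number from compound 3 to compound 4 (0.24 log units; within the scatter), so 3-chlorophenyl and 3,4-dimethylphenyl cannot be told apart at this position. Going by these compounds alone, the earlier compounds all carried a single halogen on this aryl ring, and their one measured step, a 2.5-fold higher number from compound 1 to compound 2 (0.40 log units; beyond the scatter), was a swap of one halogen for another that lay beyond the scatter; this pair shows that a ring with no halogen and two methyl groups can stay within the scatter of compound 3. Nothing measured here accounts for this outcome.

Going by these compounds, it remains open whether the aryl ring would tolerate other groups to the same degree, such as a methoxy group, a trifluoromethyl group or a nitrile, and whether chlorine and the two methyl groups would stay this close with further replacements of the shared core. On these data alone, the same exchange on the shorter chain of compound 1 is also open, so the result for compound 4 holds only for the pair with compound 3.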